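Terpenoid ester series: antiproliferative readings on breast carcinoma cells

The compounds below may be only part of what the source reports. "The series", "measured", "known", "first", "only" and "open" are said of these compounds alone.

Two measured compounds share a terpenoid core and differ in the substituent at the secondary oxygen of the pyran-type ring end. Compound 1 `CC1=CC[C@H]2[C@@H]1CC=C(C)[C@@H](CC[C@H]1[C@]3(C)CC[C@H](OCc4ccccc4)C(C)(C)O[C@H]3CC[C@@]1(C)O)C2(C)C` carries a benzyl ether there; in a functional assay on MDA-MB-231 cells (Homo sapiens) for antiproliferative activity, read by MTT assay, with a stated time of 72 h (a higher number here means a weaker inhibitor, a lower number a stronger inhibitor), compound 1 gives 35700 nM. Compound 2 `CC1=CC[C@H]2[C@H](CC[C@]2(C)O)C(C)(C)[C@@H]1CC[C@H]1[C@]2(C)CC[C@H](OC(=O)NS(=O)(=O)c3ccc(C)cc3)C(C)(C)O[C@H]2CC[C@@]1(C)O` carries a sulfonyl carbamate; in this assay compound 2 gives 47100 nM. Compound 2 holds the higher of the two numbers, but the gap to compound 1 lies within the scatter, so the two are not distinguished.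

Compound 3 `CC1=CC[C@H]2[C@H](CC[C@]2(C)O)C(C)(C)[C@@H]1CC[C@H]1[C@]2(C)CC[C@H](OC(=O)c3ccc(C(F)(F)F)cc3F)C(C)(C)O[C@H]2CC[C@@]1(C)O` is the next in line. Relative to compound 2 the change is 2-fluoro-4-(trifluoromethyl)phenyl in place of ((4-methylphenyl)sulfonyl)amino on a carbonyl carbon. For the measured compounds named here, no measured pair showing this kind of exchange exists, so there is no step to lean on; the two values available sit close together, and a substituent exchange at this position has so far moved the number little. The step from compound 2 to compound 3 is therefore expected to be small, most likely inside the scatter, as a 1.2-fold lower number from compound 2 to compound 3 (0.07 log units; within the scatter). Compound 3 is accordingly estimated at 40000 nM, with a range from 15000 nM to 100000 nM.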

Compound 3, half-maximal inhibitory concentration: 36300 nM
Estimate against measurement, compound 3: 1.1-fold (0.04 log units) above; the measured number falls inside the stated range.
By their numbers in this assay, from the lowest: compounds 1, 3 and 2 (each within the scatter of the next).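

In this assay, for the compounds shown here, the exchange of ((4-methylphenyl)sulfonyl)amino for 2-fluoro-4-(trifluoromethyl)phenyl on a carbonyl carbon gives the first step that can be read: a 1.3-fold lower number from compound 2 to compound 3 (0.11 log units; within the scatter), so this pair is not distinguished. The exchange keeps the count of 11 heavy atoms and the six-membered aromatic ring of carbon only, but it replaces the nitrogen, sulfur and oxygen atoms of the leaving group with carbon and fluorine, and the hydrogen-bond donor and acceptor counts both fall to 0, so at this place and in this pair the reading does not depend on the presence of those atoms or of the sulfonyl carbamate link. Nothing at hand bears on why the two compounds read alike.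

Going by these compounds, all of this rests on a single pair with two aromatic groups of equal heavy-atom count, so it remains open whether a group of a different kind on the same carbonyl carbon, such as a simple alkyl chain, a primary amine or a carboxylic acid, would move the number beyond the scatter. Equally open, on these data alone, is whether a smaller group at this place, such as a methyl, would read alike.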